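This account rests on a few compounds, and the source may have more. Where it says the series, first, only, none or still open, it means among the compounds named here.

Compound 1 `O=C1c2ccccc2CN1c1cnc(NCc2c(F)ccc3c2CCO3)n2cnnc12` gives 2.7 in a physicochemical assay for lipophilicity, using the shake flask method, in phosphate buffer, measured as octanol-water partition, with a stated time of 30 min, at pH 7.4 (on this read-out higher numbers stand for higher lipophilicity and lower numbers for lower lipophilicity), the second highest of the three numbers measured: compound 3 `Cc1cc(-c2cnc(NCc3c(F)ccc4c3CCO4)c3cn[nH]c(=O)c23)n(C)n1` gives 3, within the scatter of compound 1, while compound 2 `CN(C)Cc1ccc2c(c1)CN(c1cnc(NCc3c(F)ccc4c3CCO4)n3cnnc13)C2=O` gives 1.6. For the measured compounds named here, the only one-place step measured, a number 1.10 log units lower from compound 1 to compound 2 (beyond the scatter), is large, but it bears only loosely on the present change. Compound 4 `O=C1CC2(CC2)CN1c1cnc(NCc2c(F)ccc3c2CCO3)n2cnnc12` differs from compound 1 by a group of 8 heavy atoms (6 carbon, 1 nitrogen, 1 oxygen; one three-membered non-aromatic ring of carbon only, one five-membered non-aromatic ring with 1 hetero atom) in place of a group of 10 heavy atoms (8 carbon, 1 nitrogen, 1 oxygen; one five-membered non-aromatic ring with 1 hetero atom, one six-membered aromatic ring of carbon only), on an aromatic carbon. Going by the values given here, no measured step follows this exchange directly; with a six-membered aromatic ring of carbon only leaving and a three-membered non-aromatic ring of carbon only entering, a drop beyond the scatter is expected in this assay, a number 0.80 log units lower from compound 1 to compound 4 (beyond the scatter). Compound 4 is therefore estimated at 1.9, with a range of 1.3 to 2.5.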

Compound 4, distribution coefficient: 1.9
The estimate for compound 4 equals the measured number at the digits printed; the range from low to high includes it.
By their numbers in this assay, from the lowest: compounds 2 and 4 (each within the scatter of the next); then compounds 1 and 3 (each within the scatter of the next).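

In this assay, the exchange at this aromatic carbon gives a number 0.80 log units lower from compound 1 to compound 4 (beyond the scatter), so the number at this position moves beyond the scatter without the (dimethylamino)methyl group seen in compound 2. The two groups have the same counts of hydrogen-bond donors and acceptors and no net charge, yet the six-membered aromatic ring of carbon only is gone and a three-membered ring of carbon only has entered. No supporting data bear on the reason for this step.

From the compounds shown here alone, whether the loss of the aromatic ring or the entry of the three-membered ring carries the step remains open. A five-membered lactam with two methyl groups in place of the three-membered ring would help to separate the two.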